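The source may hold more compounds than are shown below. What is called first, only, known or untested is meant among the compounds shown, and "the series" means these compounds.

Measured so far:
compound 1, `O=C(CSc1nc(Nc2ccccc2)c2ccccc2n1)Nc1ccc(F)cc1`: 16500 nM
compound 2, `O=C(CSc1nc(Nc2ccccc2)c2ccccc2n1)Nc1ccc(Cl)cc1`: 8040 nM

In a functional assay on NCI-H1975 cells (Homo sapiens) for inhibition, read by MTT assay, with a stated time of 72 h (a higher number here means a weaker inhibitor, a lower number a stronger inhibitor), compound 2 gives 8040 nM, the lower of the two numbers shown. Compound 1 gives 16500 nM. Among the measured compounds shown here, the one measured step, a 2.1-fold lower number from compound 1 to compound 2 (0.31 log units; beyond the scatter), is the only one that bears on the next change, and only loosely. Compound 3, `O=C(CSc1nc(Nc2ccccc2)c2ccccc2n1)Nc1ccc(Cl)cc1Cl`, differs from compound 2 by chloro in place of hydrogen on an aromatic carbon. For the measured compounds named here, no measured step adds a second chloro to this ring, so the expectation rests on compound 2 alone: a small further decrease or none beyond the scatter, a 1.5-fold lower number from compound 2 to compound 3 (0.16 log units; within the scatter). Compound 3 is therefore estimated at 5500 nM, with a range from 2200 nM to 14000 nM.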

Compound 3, half-maximal inhibitory concentration: 8410 nM
Beside the measured number, compound 3's estimate is 1.5-fold (0.18 log units) below it; the range from low to high includes it.
By their numbers in this assay, from the lowest: compounds 2, 3 and 1 (each within the scatter of the next, the first and the last beyond it).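

In this assay, going from 4-chlorophenyl to 2,4-dichlorophenyl gives a 1.0-fold higher number from compound 2 to compound 3 (0.02 log units; within the scatter), so a chloro at this position leaves the number indistinguishable from that of the single-chloro compound. The other new step, a 2.0-fold lower number from compound 1 to compound 3 (0.29 log units; within the scatter), also lies within the scatter, unlike a 2.1-fold lower number from compound 1 to compound 2 (0.31 log units; beyond the scatter), which lies just beyond it. Nothing shown here explains this result. The compounds shown leave open whether a methoxy group or an amine at this position would shift the number beyond the scatter. They also leave open how a carboxylic acid on this ring would read.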